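Dropping the Fluoro Group from Compound 1

The source may report more compounds than this note shows. Statements on the series, on what has been measured and on what is new or still open speak of the compounds shown alone.

Among the measured compounds shown here, the two compounds measured so far share one core and differ only in the aryl group on the amine nitrogen in a ring. Compound 1 `COc1cccc(N2CCN(C(=O)c3oc(C)nc3-c3ccccc3F)CC2)c1` gives 56.1 nM in a functional assay on HL-60 cells (Homo sapiens) for inhibition, read by MTT assay, with a stated time of 72 h (on this read-out higher numbers stand for weaker inhibition and lower numbers for stronger inhibition), the lowest of the two numbers. Compound 2 `COc1ccc(Cl)cc1N1CCN(C(=O)c2oc(C)nc2-c2ccccc2F)CC1` gives 153 nM in this assay; the step of a 2.7-fold higher number from compound 1 to compound 2 (0.44 log units; beyond the scatter) is modest but beyond the scatter, and it comes from 5-chloro-2-methoxyphenyl in place of 3-methoxyphenyl on that nitrogen.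

Compound 3 `COc1cccc(N2CCN(C(=O)c3oc(C)nc3-c3ccccc3)CC2)c1` has not been measured. It differs from compound 1 in another part of the molecule: hydrogen in place of fluoro on an aromatic carbon, that is, 2-fluorophenyl becomes phenyl. For the measured compounds named here, no measured step touches this fluoro group, so the only measured change, from compound 1 to compound 2, concerns a different ring and gives no direct guide. With nothing to suggest a large shift, the step of a 1.4-fold higher number from compound 1 to compound 3 (0.15 log units; within the scatter) is expected to stay within or near the scatter, if anything toward a somewhat higher number. Compound 3 is therefore estimated at 80 nM, with a range from 30 nM to 220 nM.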

Compound 3, half-maximal inhibitory concentration: 34.8 nM
Beside the measured number, compound 3's estimate is 2.3-fold (0.36 log units) above it, and the stated range covers the measured number.
By their numbers in this assay, from the lowest: compounds 3 and 1 (each within the scatter of the next); then compound 2.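

In this assay, among the compounds shown here, the result gives a 1.6-fold lower number from compound 1 to compound 3 (0.21 log units; within the scatter) and so provides the first measured look at this aromatic carbon, ortho to a large group: with hydrogen in place of fluoro, compound 1 and compound 3 cannot be told apart, so the fluoro group is not required for a number in this range. The two changes measured so far also differ in what they do, since the aryl group on the amine nitrogen in a ring gives a 2.7-fold higher number from compound 1 to compound 2 (0.44 log units; beyond the scatter) and so lies beyond the scatter, whereas 2-fluorophenyl to phenyl stays within it. Nothing measured here explains why this position tolerates the change, and no data on the properties of either compound bear on the result.

As far as these compounds go, whether a larger or charged group, such as a carboxylic acid, an aminomethyl group or a nitrile, would be tolerated equally well on this aromatic carbon remains open. From the compounds shown here alone, it is also open whether hydrogen in place of fluoro would leave the number similarly unmoved with the 5-chloro-2-methoxyphenyl group of compound 2 on the nitrogen.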